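The source may hold more compounds than are shown below. What is called first, only, known or untested is meant among the compounds shown, and "the series" means these compounds.

Measured so far in an ADME assay on microsomes from liver (Homo sapiens) for metabolic stability, read by HPLC, with a stated time of 10 min, tested at 3 uM; a higher number here means that more of the compound is left, a lower number that less of the compound is left:
- compound 1 `COC[C@@H](C1CC1)n1cc(Cl)nc(Nc2cc(C)c(OC)nc2C)c1=O` gives 40%
- compound 2 `COc1nc(C)c(Nc2nc(Cl)cn([C@H](C)C3CC3)c2=O)cc1C` gives 77%

Compound 2 holds the higher of the two numbers, with 77% in this assay and nothing measured above it. The next structure is compound 3 `COc1nc(C)c(Nc2nc(C#N)cn([C@H](C)C3CC3)c2=O)cc1C` and its change from compound 2 is cyano in place of chloro on an aromatic carbon in short, cyano in place of chloro on an aromatic carbon, next to the ring nitrogen.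

Going by the values given here, the only measured step (a number 37 percentage points higher from compound 1 to compound 2 (beyond the scatter)) is large and beyond the scatter, but it concerns the group on an aromatic nitrogen, not this carbon. Among the compounds with values here, it therefore bears on the new change only indirectly, and no measured pair shows what this exchange does. No direction can be argued from the data, so the expected step (a number 1 percentage points higher from compound 2 to compound 3 (within the scatter)) stays within the scatter, with a wide range. For compound 3 the estimated value is 78% (expected range 60% to 92%).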

Compound 3, percent of the compound remaining: 99%
Compound 3: the middle estimate sits 21 percentage points below what was measured, and the stated range ends below it.
By their numbers in this assay, from the lowest: compound 1; then compound 2; then compound 3.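

The aromatic carbon next to the ring nitrogen proves to be a position that matters in this assay: with the 1-cyclopropylethyl group and the rest of the structure held constant, cyano in place of chloro gives a number 22 percentage points higher from compound 2 to compound 3 (beyond the scatter). The series therefore has a second site of change that moves this read-out beyond the scatter, in addition to the group on the aromatic nitrogen, and compound 3 at 99% leaves little room for any further rise on this percent scale. No measurement at hand explains the rise.

On these data alone, whether the cyano gain carries over to the 1-cyclopropyl-2-methoxyethyl group of compound 1 remains open. So does how a methyl, an amine or a carboxylic acid on this carbon would compare with chloro and cyano.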